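The source may hold more compounds than are shown below. What is called first, only, known or untested is meant among the compounds shown, and "the series" means these compounds.

Measured so far in a functional assay on MCF7 cells (Homo sapiens) for inhibition, read by CCK-8 assay; on this read-out higher numbers stand for weaker inhibition and lower numbers for stronger inhibition:
compound 1 `Oc1ccccc1/C=N/c1nnc(SCc2nnc(-c3ccccc3Cl)o2)s1` — 18100 nM
compound 2 `Oc1ccccc1/C=N/c1nnc(SCc2nnc(-c3ccccc3Br)o2)s1` — 9140 nM

Compound 1 gives the highest of the two numbers; its nearest neighbour is compound 2, and the step of a 2.0-fold lower number from compound 1 to compound 2 (0.30 log units; within the scatter) is within the scatter, so the two cannot be ordered.

Compound 3 `O=[N+]([O-])c1cccc(-c2nnc(CSc3nnc(/N=C/c4ccccc4O)s3)o2)c1` is not yet measured. Against compound 1 the change is 3-nitrophenyl in place of 2-chlorophenyl on an aromatic carbon. Going by the values given here, no measured step bears directly on this change: the single step available, a 2.0-fold lower number from compound 1 to compound 2 (0.30 log units; within the scatter), swaps one halogen for another at the same aromatic carbon and stays within the scatter, whereas here the whole 2-chlorophenyl is exchanged for 3-nitrophenyl. No direction is therefore supported, and the step of a 1.3-fold lower number from compound 1 to compound 3 (0.11 log units; within the scatter) is expected to be small, with a wide range to allow for the larger change. Compound 3 is estimated at 14000 nM, between 4000 nM and 45000 nM.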

Compound 3, half-maximal inhibitory concentration: 13900 nM
Compound 3: the middle estimate sits 1.0-fold (0.00 log units) above what was measured, within the range that was stated.
By their numbers in this assay, from the lowest: compounds 2, 3 and 1 (each within the scatter of the next).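

Going by these compounds alone, on an aromatic carbon of the five-membered aromatic ring with 2 nitrogen and 1 oxygen, the earlier compounds covered only an exchange of one halogen for another. In this assay, replacing the halogenated phenyl with 3-nitrophenyl gives two steps that stay within the scatter: a 1.3-fold lower number from compound 1 to compound 3 (0.11 log units; within the scatter) and a 1.5-fold higher number from compound 2 to compound 3 (0.18 log units; within the scatter) so the three compounds cannot be ordered, even though the entering group brings 2 hydrogen-bond acceptors and the leaving groups bring none. No available evidence explains this result.

The substituent and its place on the phenyl ring both differ in this exchange, so the compounds shown cannot separate the two. Also open, going by these compounds, is whether an amine or a carboxylic acid in place of the whole phenyl group at this carbon would give a step beyond the scatter.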